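This account rests on a few compounds, and the source may have more. Where it says the series, first, only, none or still open, it means among the compounds named here.

- Compound 1 `C=C[C@@]1(C)[C@H]2OC(=O)C(=C)[C@H]([C@@H]2OC(C)=O)[C@H](OC(=O)C(C)(C)O)[C@@H]1C(=C)C=O`: 640 nM
- Compound 2 `C=C1C(=O)O[C@H]2[C@@H](OC(C)=O)[C@@H]1[C@H](OC(=O)C(C)(C)O)[C@H](C(=C)C=O)[C@@]2(C)[C@@H]1CO1`: 760 nM

In an ADME assay on WI-38 cells (Homo sapiens) for cytotoxicity, read by MTT assay, with a stated time of 24 h (a lower number here means a stronger inhibitor, a higher number a weaker inhibitor), compound 2 gives 760 nM, level within the scatter with compound 1 at 640 nM. Compound 3 `C=C1C(=O)O[C@H]2[C@@H](OC(C)=O)[C@@H]1[C@H](OC(=O)C(C)(O)CC)[C@H](C(=C)C=O)[C@@]2(C)[C@@H]1CO1` carries one change from compound 2: methyl in place of hydrogen on a saturated chain carbon, two bonds along the chain from a carbonyl carbon and an oxygen on a saturated carbon. Among the measured compounds shown here, no measured step covers this change. The only one, a 1.2-fold higher number from compound 1 to compound 2 (0.07 log units; within the scatter), is oxiran-2-yl in place of vinyl on a saturated ring carbon, and it stays within the scatter. No shift beyond the scatter is therefore expected in this assay, and the estimated step is a 1.1-fold lower number from compound 2 to compound 3 (0.04 log units; within the scatter). Compound 3 is estimated at 700 nM, with an expected range of 350 nM to 1400 nM.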

Compound 3, half-maximal inhibitory concentration: 690 nM
Estimate against measurement, compound 3: 1.0-fold (0.01 log units) above; the measured number falls inside the stated range.
By their numbers in this assay, from the lowest: compounds 1, 3 and 2 (each within the scatter of the next).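

In this assay, the change from methyl to ethyl, which turns 1-hydroxy-1-methylethyl into 1-hydroxy-1-methylpropyl, gives a 1.1-fold lower number from compound 2 to compound 3 (0.04 log units; within the scatter). Among the compounds shown here, this is the first reading at this position, and it shows that the position takes the added methyl without a shift beyond the scatter. No further data bear on this result.

For the compounds shown here, only the step from methyl to ethyl is covered here. From the compounds shown here alone, whether a longer chain such as butyl, or an amine in place of the hydroxy group, would also stay within the scatter remains open.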